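A few compounds are considered here, and "the series" means these few. Any claim that something is new, unique, unknown or untested is made for them only; others in the source may bear on it.

Among the compounds with values here, compound 3 `CC(C)(C)c1ccc(C(=O)N2CCC3(CC2)C(=O)N(CC(=O)NCCC(=O)O)CN3c2ccccc2)cc1` holds the highest number of the three measured so far in an assay on HEK293 cells for displacement of a labelled ligand from NPC1-like intracellular cholesterol transporter 1 (Homo sapiens); on this read-out higher numbers stand for weaker inhibition and lower numbers for stronger inhibition: compound 3 gives 11400 nM, compound 1 `CC(C)(C)c1ccc(C(=O)N2CCC3(CC2)C(=O)N(CC(=O)NCCN)CN3c2ccccc2)cc1` gives 7000 nM, and compound 2 `CCOC(=O)C1CCN(C(=O)CN2CN(c3ccccc3)C3(CCN(C(=O)c4ccc(C(C)(C)C)cc4)CC3)C2=O)CC1` gives 3100 nM. Compound 4 `CCC1CCCN(C(=O)CN2CN(c3ccccc3)C3(CCN(C(=O)c4ccc(C(C)(C)C)cc4)CC3)C2=O)C1` carries the change (3-ethylpiperidin-1-yl in place of (2-carboxyethyl)amino on a carbonyl carbon). Within the data shown here, two measured steps bear on it: a 3.7-fold higher number from compound 2 to compound 3 (0.57 log units; beyond the scatter) and a 2.3-fold lower number from compound 1 to compound 2 (0.35 log units; beyond the scatter), both of which place a piperidinyl group on the carbonyl carbon at a lower number than an open amino chain in the same place. A downward step of similar size is therefore expected for the 3-ethylpiperidin-1-yl group, and the step is estimated as a 3.3-fold lower number from compound 3 to compound 4 (0.51 log units; beyond the scatter). Compound 4 is expected to give 3500 nM, with a range from 1500 nM to 9000 nM.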

Compound 4, half-maximal inhibitory concentration: 3900 nM
The estimate for compound 4 lay 1.1-fold (0.05 log units) below the measured number; measured number inside the range.
By their numbers in this assay, from the lowest: compounds 2, 4, 1 and 3 (each within the scatter of the next, the first and the last beyond it).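

Working notes: in this assay, the 3-ethylpiperidin-1-yl group on this carbonyl carbon shows a 2.9-fold lower number from compound 3 to compound 4 (0.47 log units; beyond the scatter), and a 1.3-fold higher number from compound 2 to compound 4 (0.10 log units; within the scatter) shows that the ethoxycarbonyl group of compound 2 is not needed to stay within the scatter of that compound. The gain over an open chain is not general, as a 1.8-fold lower number from compound 1 to compound 4 (0.25 log units; within the scatter) stays within the scatter and compound 1 goes against it. Nothing available explains these steps. Open remains how an unsubstituted piperidin-1-yl, or a piperidine ring carrying a carboxylic acid or an amine, would read on this carbonyl carbon.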